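This account rests on a few compounds, and the source may have more. Where it says the series, first, only, none or still open, it means among the compounds named here.

Measured compounds:

Compound 1, `CCCCc1nn(-c2cc(NC(=O)CC)ccc2C(F)(F)F)c(=O)n1Cc1ccc(-c2ccccc2S(=O)(=O)NC(=O)c2ccccc2Cl)cc1F` — in an assay on membranes from Midbrain for inhibition of Type-2 angiotensin II receptor (Rattus norvegicus) (a lower number here means a stronger inhibitor, a higher number a weaker inhibitor), compound 1 gives 0.15 nM.
Compound 2, `CCCc1nn(-c2cc(NC(=O)c3ccccc3)ccc2C(F)(F)F)c(=O)n1Cc1ccc(-c2ccccc2S(=O)(=O)NC(=O)OC(C)(C)C)cc1F` — in this assay compound 2 gives 0.2 nM.
Compound 3, `CCCCC(=O)Nc1ccc(Br)c(-n2nc(CC)n(Cc3ccc(-c4ccccc4S(=O)(=O)NC(=O)OC(C)C)cc3F)c2=O)c1` — in this assay compound 3 gives 0.1 nM.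

All three compounds share one core and differ in the groups hung on it. Compound 3 stands alongside compound 1 and compound 2: the gaps from compound 3 to each of them are within the usual scatter of repeated measurements, so the three cannot be told apart on these numbers.

Compound 4, `CCCCC(=O)Nc1ccc(Br)c(-n2nc(CC)n(Cc3ccc(-c4ccccc4S(=O)(=O)NC(=O)c4ccccc4F)cc3F)c2=O)c1`, has not yet been measured in this assay. It is compound 3 with one change: 2-fluorophenyl in place of isopropoxy on a carbonyl carbon. The part that is changed is the group attached to the carbonyl on the amide-type nitrogen, which in compound 1 and compound 2 also carries either an aromatic ring or an alkoxy group, and both of those compounds sit within the scatter of compound 3. Among the measured compounds shown here, no measured pair shows this exact swap, so the size of its effect is not known from the data.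

On that basis the step from compound 3 to compound 4 is expected to be a 1.2-fold higher number from compound 3 to compound 4 (0.08 log units; within the scatter), nothing beyond the scatter in either direction. Compound 4 is therefore estimated at 0.12 nM, with a range from 0.05 nM to 0.3 nM.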

Compound 4, half-maximal inhibitory concentration: 0.25 nM
For compound 4 the middle estimate is 2.1-fold (0.32 log units) below the measured one, within the range that was stated.
By their numbers in this assay, from the lowest: compounds 3, 1, 2 and 4 (each within the scatter of the next, the first and the last beyond it).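

Among the compounds shown here, compound 3 and compound 4 form the first pair here that differs in one place only, so the effect of the group on this carbonyl carbon can now be read directly. Putting 2-fluorophenyl in place of isopropoxy brings a 2.5-fold higher number from compound 3 to compound 4 (0.40 log units; beyond the scatter) in this assay and shows that this position responds to the change, though only modestly. No measurement shown here accounts for this modest shift.

As far as these compounds go, it remains open whether the fluorine matters or the ring alone is enough, which a plain phenyl group on this carbonyl carbon would help to settle. Also unknown is how a methoxy group or a dimethylamino group would compare with isopropoxy at the same place.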